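A few compounds are considered here, and "the series" means these few. Any claim that something is new, unique, unknown or untested is made for them only; others in the source may bear on it.

Compound 1 `CCn1c(SCc2cc([N+](=O)[O-])ccc2OC)nc2cc(NC(=O)NC(C)(C)C)ccc21` gives 42 nM in an assay on isolated protein for inhibition of Gonadotropin-releasing hormone receptor (Homo sapiens); on this read-out higher numbers stand for weaker inhibition and lower numbers for stronger inhibition.
Compound 2 `CCCn1c(SCc2cc([N+](=O)[O-])ccc2OC)nc2cc(NC(=O)NC(C)(C)C)ccc21` gives 18 nM.
Compound 3 `COCCn1c(SCc2cc([N+](=O)[O-])ccc2OC)nc2cc(NC(=O)NC(C)(C)C)ccc21` gives 57 nM.

Among these three compounds, compound 3 has the highest number in this assay; it differs from compound 1 by a 1.4-fold higher number from compound 1 to compound 3 (0.13 log units; within the scatter), a gap within the scatter, and from compound 2 by a 3.2-fold higher number from compound 2 to compound 3 (0.50 log units; beyond the scatter). Compound 4 `COc1ccc([N+](=O)[O-])cc1CSc1nc2cc(NC(=O)NC(C)(C)C)ccc2n1Cc1ccccc1` is not yet measured. It differs from compound 3 in one place: phenyl in place of methoxymethyl on a saturated chain carbon bound to an aromatic nitrogen. Among the compounds with values here, two measured steps bear on this change, both at the same chain carbon. Adding carbon gave a 2.3-fold lower number from compound 1 to compound 2 (0.37 log units; beyond the scatter), whereas replacing methyl by methoxy gave a 3.2-fold higher number from compound 2 to compound 3 (0.50 log units; beyond the scatter). Compound 4 removes the methoxy oxygen and adds a larger carbon-only group, so the two steps together point toward a lower number. Within the data shown here, compound 4 is therefore expected to show a modest step down, a 2.3-fold lower number from compound 3 to compound 4 (0.36 log units; beyond the scatter), beyond the scatter but not large, since no measured step here exceeded that size. The estimate for compound 4 in this assay is 25 nM, with a range from 8 nM to 80 nM.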

Compound 4, half-maximal inhibitory concentration: 28 nM
Estimate against measurement, compound 4: 1.1-fold (0.05 log units) below; low and high end bracket the measured number.
By their numbers in this assay, from the lowest: compounds 2, 4, 1 and 3 (each within the scatter of the next, the first and the last beyond it).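

In this assay, the saturated chain carbon bound to an aromatic nitrogen takes a benzyl group, with its six-membered aromatic ring of carbon only, and the number stays level with those of the two plain carbon chains: a 1.6-fold higher number from compound 2 to compound 4 (0.19 log units; within the scatter), and a 1.5-fold lower number from compound 1 to compound 4 (0.18 log units; within the scatter). Set against the 2-methoxyethyl group, the same change gives a 2.0-fold lower number from compound 3 to compound 4 (0.31 log units; beyond the scatter), so compound 3, the one compound with an oxygen in this chain, is the only one of the series beyond the scatter of compound 4. Nothing available explains why the ring is accommodated here.

Open, going by these compounds, is whether a longer chain such as butyl, or a phenethyl group, would stay in this range. So is the outcome for a benzyl ring carrying a methoxy group, or for a chain ending in an amine or a carboxylic acid.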